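The compounds below may be only part of what the source reports. "The series", "measured", "known", "first", "only" and "open" are said of these compounds alone.

Measured so far:
- compound 1 `CC(C)NC(=O)NCCS(=O)(=O)NC(=O)c1ccc(Nc2nc(NC3(c4ccc(Cl)cc4)CC3)nc(OCC(F)(F)F)n2)cc1`: 97%
- compound 2 `O=C(NS(=O)(=O)C1CC1)c1ccc(Nc2nc(NC3(c4ccc(Cl)cc4)CC3)nc(OCC(F)(F)F)n2)cc1`: 85%

In an ADME assay on microsomes from liver (Rattus norvegicus) for metabolic stability, with a stated time of 10 min (a higher number here means that more of the compound is left, a lower number that less of the compound is left), compound 1 gives 97% and compound 2 gives 85%. Compound 2 thus stands at the lower of the two numbers, with compound 1 the nearest and the only other point; the step of a number 12 percentage points lower from compound 1 to compound 2 (beyond the scatter) puts that gap beyond the scatter, though it remains modest.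

Compound 3 `Cc1ccccc1S(=O)(=O)NC(=O)c1ccc(Nc2nc(NC3(c4ccc(Cl)cc4)CC3)nc(OCC(F)(F)F)n2)cc1` is not yet measured. Its difference from compound 2 is 2-methylphenyl in place of cyclopropyl on a sulfonyl sulfur. Within the data shown here, the single measured step, a number 12 percentage points lower from compound 1 to compound 2 (beyond the scatter), concerns the same sulfonyl substituent and is the only one that bears on this change; it shows that exchanging the group on that sulfur moved the number by a modest amount. Nothing measured here addresses an aromatic substituent at this position, so the direction is open. With two points only, a step of similar modest size is expected for compound 3, most plausibly downward or within the scatter, as a number 7 percentage points lower from compound 2 to compound 3 (within the scatter). Compound 3 is therefore estimated at 78%, in the range 55% to 95%.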

Compound 3, percent of the compound remaining: 100%
For compound 3 the middle estimate is 22 percentage points below the measured one; the whole stated range lies below it.
By their numbers in this assay, from the lowest: compound 2; then compounds 1 and 3 (each within the scatter of the next).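

Exchanging cyclopropyl for 2-methylphenyl on the sulfonyl sulfur gives a number 15 percentage points higher from compound 2 to compound 3 (beyond the scatter) in this assay, so an aromatic ring at this place does not lower the number, and the change from cyclopropyl can go upward as well as downward. Compared with the open chain, the same ring gives a number 3 percentage points higher from compound 1 to compound 3 (within the scatter), so 2-((isopropylcarbamoyl)amino)ethyl and 2-methylphenyl cannot be told apart here despite their very different shapes of substituent, and among these three groups only cyclopropyl stands apart from both others beyond the scatter. Nothing in the data on these compounds speaks to the origin of these differences.

Open, on these data alone, is whether the result belongs to the aromatic ring itself or to its methyl group, which an unsubstituted phenyl or a 2-chlorophenyl on the same sulfur would separate. Also open, as far as these compounds go, is whether cyclopropyl is a single low point or part of a trend among small carbon groups, which a methyl, an ethyl or a cyclohexyl at this place would begin to answer.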